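Drawn Configuration and Cell Toxicity in a Small Series

A few compounds are considered here, and "the series" means these few. Any claim that something is new, unique, unknown or untested is made for them only; others in the source may bear on it.

This short study concerns four related compounds and one question: how strongly they harm human lung fibroblast cells, as measured in an ADME assay on MRC5 cells (Homo sapiens) for cytotoxicity, read by WST assay, with a stated time of 48 h; a lower number here means a stronger inhibitor, a higher number a weaker inhibitor. Going by the values given here, compound 1 `CC1=CC(=O)[C@]2(O1)C(=O)N[C@@](O)(CC(C)C)[C@@H]2O` is the only member with a result, and that result is a limit of the assay rather than a number: compound 1 gives > 50000 nM in this assay. Compound 2 `CC1=CC(=O)[C@@]2(O[C@H]2C(=O)CC(C)C)C(=O)N1` has no reported value, "not determined" (no result reported). Compound 3 `CC1=CC(=O)[C@]2(O[C@@H]2C(=O)CC(C)C)C(=O)N1` likewise stands without a result, "not determined" (no result reported) in this assay. Its position among the shown numbers therefore rests only on the observation that the single real measurement in the set is a limit (the limit of > 50000 nM in this assay, at which 1 of the 3 values shown sits), and on the relation between compound 2 and compound 3 given by the fact that compounds 2 and 3 differ only in the configuration as drawn. Among the compounds with values here, compound 4 `CC1=CC(=O)C2(OC2C(=O)CC(C)C)C(=O)N1` is the compound still to be measured. the two compounds have the same atoms and bonds; at least one stereo element is drawn with a configuration in one of them and without one in the other: 2 of 2 stereo elements differ; a stereocentre at a saturated ring carbon is drawn S in compound 3 and without a configuration in compound 4; a stereocentre at a saturated ring carbon is drawn S in compound 3 and without a configuration in compound 4 No step between measured compounds exists, so no size or direction can be read from the data; a change only in drawn configuration, with the same atoms and bonds, is expected to give a difference within the usual scatter, or none at all. Compound 4 is therefore expected to give about 50000 nM in this assay, with a likely range from 15000 nM to 100000 nM. Most probably only a limit will be reported for compound 4, as for compound 1.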

Compound 4, half-maximal inhibitory concentration: 33200 nM
The estimate for compound 4 lay 1.5-fold (0.18 log units) above the measured number; the measured number falls inside the stated range.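

No step can be read from the result for compound 4: compound 2 and compound 3, which share its atoms and bonds, carry no number to set beside it in this assay. The compounds shown leave open whether the drawn configuration at the two saturated ring carbons changes the toxicity to these cells at all.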